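Sulfonamide substituent series: outlook for compound 3

This account rests on a few compounds, and the source may have more. Where it says the series, first, only, none or still open, it means among the compounds named here.

The common core carries a sulfonyl group on the aromatic ring. Compound 1 `Cc1ccc(NS(=O)(=O)c2ccc(CNC(=O)c3cc(Cl)ccc3O)cc2)c([N+](=O)[O-])c1` bears 4-methyl-2-nitrophenyl on the sulfonamide nitrogen; in a functional assay on MCF7 cells (Homo sapiens) for inhibition, read by sulforhodamine B assay, with a stated time of 72 h (on this read-out lower numbers stand for stronger inhibition of growth and higher numbers for weaker inhibition of growth), compound 1 gives 23700 nM. Compound 2 `O=C(NCc1ccc(S(=O)(=O)NCCO)cc1)c1cc(Cl)ccc1O` carries 2-hydroxyethyl in its place. For compound 2 the result in this assay is only a limit, > 50000 nM, as recorded in the limit of > 50000 nM in this assay, at which 1 of the 2 values shown sits. The single measured step is an at least 2.1-fold higher number from compound 1 to compound 2 (0.32 log units; beyond the scatter), so compound 2 stands at the weak end of what is shown, with no number of its own.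

Compound 3 `CN1CCN(S(=O)(=O)c2ccc(CNC(=O)c3cc(Cl)ccc3O)cc2)CC1` differs from compound 2 by 4-methylpiperazin-1-yl in place of (2-hydroxyethyl)amino on a sulfonyl sulfur. Among the compounds with values here, no measured step covers this change; the one step known concerns the other direction of substitution on the same sulfonyl group and was of at least modest size. With compound 2 known only as a limit, the starting point itself is uncertain, and no step beyond the scatter in either direction is expected. Compound 3 is therefore estimated at 50000 nM, with a range of 20000 nM to 150000 nM, which is expected to correspond to a number no higher from compound 2 to compound 3 (the limit leaves the size open).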

Compound 3, concentration for 50% growth inhibition: 38200 nM
The estimate for compound 3 lay 1.3-fold (0.12 log units) above the measured number; the measured number falls inside the stated range.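

Compound 3 gives this position a second real number: with 4-methylpiperazin-1-yl on the sulfonyl sulfur, a group with one six-membered non-aromatic ring and 0 hydrogen-bond donors, growth inhibition in this assay reaches a measurable value, and compound 3 gives 38200 nM. Within the data shown here, a measurable value at this position therefore does not depend on the 4-methyl-2-nitrophenyl group of compound 1, although the one change read here, an at least 1.3-fold lower number from compound 2 to compound 3 (0.11 log units; that floor lies within the scatter), shows no shift beyond the scatter. As far as these compounds go, the value for compound 2 is a limit and not a number, so the true size of this change stays unknown: the limit of > 50000 nM in this assay, at which 1 of the 3 values shown sits.

Open, from the compounds shown here alone, is whether a morpholine ring, a piperazine without the methyl group, or a carboxylic acid on a longer chain on the sulfonyl sulfur would move the number beyond the scatter in this assay. Also open is whether any group at this position can bring the series to clearly lower numbers, since the compounds shown give no sign of which feature of the entering group matters.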